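Cyclobutyl for isopropyl on the ring nitrogen of compound 2

The source may hold more compounds than are shown below. What is called first, only, known or untested is meant among the compounds shown, and "the series" means these compounds.

Compound 2 `CC(C)c1onc(-c2c(Cl)cccc2Cl)c1COc1ccc(-c2nc3ccc(C(=O)O)cc3n2C(C)C)cc1` was tested in an assay on Huh-7 cells for agonist activity at Bile acid receptor (Homo sapiens), read by a luciferase reporter (a lower number here means that less compound is needed, a higher number that more compound is needed for the effect), and gave 3.39 nM. Among the three measured compounds it holds the second highest number. Compound 3 `CCC(CC)n1c(-c2ccc(OCc3c(-c4c(Cl)cccc4Cl)noc3C(C)C)cc2F)nc2ccc(C(=O)O)cc21` gives 1.3 nM in this assay, a lower number beyond the scatter, while compound 1 `CC(C)c1onc(-c2c(Cl)cccc2Cl)c1COc1ccc(-c2nc3cc(C(=O)O)ccc3n2C)cc1` gives 25.8 nM, a higher number beyond the scatter. Compound 3 carries a larger group on the aromatic nitrogen than compound 2, and compound 1 a smaller one, though compound 3 also differs elsewhere, so no single change can be read from that pair.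

The step to compound 4 `CC(C)c1onc(-c2c(Cl)cccc2Cl)c1COc1ccc(-c2nc3ccc(C(=O)O)cc3n2C2CCC2)cc1` changes only one place: cyclobutyl in place of isopropyl on an aromatic nitrogen. Within the data shown here, no measured pair here differs in a single place, so the size of this step has to be judged from the three values alone. The expectation is a small step in this assay, toward a lower number or none beyond the scatter, a 1.4-fold lower number from compound 2 to compound 4 (0.13 log units; within the scatter). Compound 4 is estimated at 2.5 nM, within a range from 0.8 nM to 8 nM.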

Compound 4, half-maximal effective concentration: 14.4 nM
For compound 4 the middle estimate is 5.8-fold (0.76 log units) below the measured one, outside the stated range (above it).
By their numbers in this assay, from the lowest: compound 3; then compound 2; then compounds 4 and 1 (each within the scatter of the next).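

In this assay, among these compounds, the change on the aromatic nitrogen gives a 4.2-fold higher number from compound 2 to compound 4 (0.63 log units; beyond the scatter) and, being beyond the scatter, is the first change at this position that can be read on its own. It shows that this position responds to the exchange of isopropyl for cyclobutyl, and that a group with more heavy atoms does not by that fact give a lower number here. Nothing on hand accounts for this step.

Among the compounds shown here, the single pair leaves open whether the number follows the four-membered ring itself or the added carbon, and cyclopropyl, cyclopentyl or an open chain such as sec-butyl on the same nitrogen of compound 2 would separate these readings. On these data alone, how far the step would carry over to a core with other changes also stays open.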